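A few compounds are considered here, and "the series" means these few. Any claim that something is new, unique, unknown or untested is made for them only; others in the source may bear on it.

Values so far in a functional assay on the whole organism for antagonist activity, with Mus musculus as the target; a lower number here means that less compound is needed, a higher number that more compound is needed for the effect:
Compound 1 `CC(=O)NCC(=O)N(C)c1ccc(Cl)cc1C(=O)c1ccccc1Cl` gives 2.3 mg/kg
Compound 2 `CCC(=O)NCC(=O)N(C)c1ccc(Cl)cc1C(=O)c1ccccc1Cl` gives 1.4 mg/kg
Compound 3 `CCCCCCC(=O)NCC(=O)N(C)c1ccc(Cl)cc1C(=O)c1ccccc1Cl` gives 1.9 mg/kg

Compound 3 is not separated from the other two numbers: neither a 1.2-fold lower number from compound 1 to compound 3 (0.08 log units; within the scatter) nor a 1.4-fold higher number from compound 2 to compound 3 (0.13 log units; within the scatter) sets it apart in this assay at this stage.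

Compound 4 `CCCCC(=O)NCC(=O)N(C)c1ccc(Cl)cc1C(=O)c1ccccc1Cl` differs from compound 3 by hydrogen in place of ethyl on a saturated chain carbon, four bonds along the chain from a carbonyl carbon. Its chain is shorter than that of compound 3 and longer than that of compound 2. The steps bearing on this change are a 1.4-fold higher number from compound 2 to compound 3 (0.13 log units; within the scatter) and a 1.6-fold lower number from compound 1 to compound 2 (0.22 log units; within the scatter) and neither leaves the scatter. No step beyond the scatter is therefore expected in this assay for this change. The expected step is a 1.1-fold lower number from compound 3 to compound 4 (0.05 log units; within the scatter) and it would not separate the two compounds. Compound 4 is estimated at 1.7 mg/kg with an expected range of 1 mg/kg to 2.9 mg/kg.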

Compound 4, dose for half-maximal effect: 1.3 mg/kg
Beside the measured number, compound 4's estimate is 1.3-fold (0.12 log units) above it; low and high end bracket the measured number.
By their numbers in this assay, from the lowest: compounds 4, 2, 3 and 1 (each within the scatter of the next).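

In this assay, replacing ethyl with hydrogen on a saturated chain carbon, four bonds along the chain from a carbonyl carbon, gives a 1.5-fold lower number from compound 3 to compound 4 (0.16 log units; within the scatter) and does not separate the two compounds. Compound 4 is also not separated from its shorter-chain neighbours by a 1.1-fold lower number from compound 2 to compound 4 (0.03 log units; within the scatter) or by a 1.8-fold lower number from compound 1 to compound 4 (0.25 log units; within the scatter) and so, across compounds 1 to 4, no chain length at this position stands apart in this assay. No supporting evidence bears on this result.

As far as these compounds go, whether a chain longer than that of compound 3 would leave the scatter remains open. So does whether an amine, a carboxylic acid or a phenyl ring at the chain end would give a step beyond it in this assay on the shared core.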